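A Ring Replaces a Flexible Chain on the Ether Oxygen

This account rests on a few compounds, and the source may have more. Where it says the series, first, only, none or still open, it means among the compounds named here.

Compound 3 has the structure `NCCOCCOc1ccc([C@H]2CC[C@]3(CC2)OOC2(O3)C3CC4CC(C3)CC2C4)cc1`. In an ADME assay on microsomes from liver (Homo sapiens) for metabolic stability, read by LC-MS, tested at 1 uM (on this read-out higher numbers stand for fast clearance and lower numbers for slow clearance), compound 3 gives < 7 mL.min-1.g-1, which is a limit of the assay rather than a number. Compound 1, with the structure `NCCCCCOc1ccc([C@H]2CC[C@]3(CC2)OOC2(O3)C3CC4CC(C3)CC2C4)cc1`, is a close relative. In this assay compound 1 also gives < 7 mL.min-1.g-1, again a limit. Compound 2, with the structure `O=S(=O)(c1ccc([C@H]2CC[C@]3(CC2)OOC2(O3)C3CC4CC(C3)CC2C4)cc1)N1CCNCC1`, carries a (piperazin-1-yl)sulfonyl group instead and is the only one of the three with a number: in this assay compound 2 gives 16 mL.min-1.g-1. The steps among these three read as follows: an at least 2.2-fold higher number from compound 1 to compound 2 (0.35 log units; beyond the scatter); an at least 2.2-fold lower number from compound 2 to compound 3 (0.35 log units; beyond the scatter); and a step that the two limits leave unreadable from compound 1 to compound 3, since both compounds sit at the limit of < 7 mL.min-1.g-1 in this assay, at which 2 of the 3 values shown sit.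

Compound 4, not yet measured, has the structure `N[C@H]1CC[C@H](Oc2ccc([C@H]3CC[C@]4(CC3)OOC3(O4)C4CC5CC(C4)CC3C5)cc2)CC1`. The change from compound 3 is 4-aminocyclohexyl in place of 2-(2-aminoethoxy)ethyl on an oxygen on an aromatic ring. For the measured compounds named here, of the measured steps, only the one from compound 1 to compound 3 keeps an amine-bearing group on the ether oxygen, and that step cannot be read; the other two steps swap the whole group for the sulfonyl piperazine, so they speak only indirectly. The expected outcome is therefore a number no lower from compound 3 to compound 4 (the limit leaves the size open), a step judged likely to stay within the scatter or to rise only slightly. Compound 4 is estimated at 7 mL.min-1.g-1, with a range from 3 mL.min-1.g-1 to 18 mL.min-1.g-1.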

Compound 4, intrinsic clearance in microsomes: < 7 mL.min-1.g-1
Compound 4 gave a limit, no number; the forecaster's own chance of this, stated with the estimate: 50%; the middle value lies on the limit itself.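

A ring can take the place of the flexible chains on the oxygen on an aromatic ring without lifting the read-out off the limit: in this assay compound 4, with its 4-aminocyclohexyl group, gives < 7 mL.min-1.g-1, which is a limit of the assay and not a number. Replacing the (piperazin-1-yl)sulfonyl group gives an at least 2.2-fold lower number from compound 2 to compound 4 (0.35 log units; beyond the scatter), so the lower read-out seen with the open chains of compound 1 and compound 3 now also appears with a group built on a six-membered non-aromatic ring of carbon only. The steps to compound 4 from compound 1 and from compound 3 cannot be read, because all three compounds stand at the same limit: the limit of < 7 mL.min-1.g-1 in this assay, at which 3 of the 4 values shown sit.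

Any real difference among these three amine-bearing ethers stays hidden, so the shown compounds cannot rank ring against chain. Also open, as far as these compounds go, is how a piperidin-4-yl group, or a plain cyclohexyl group without the amine, would read on the same oxygen, and whether the other stereoisomer of the 4-aminocyclohexyl group would read the same.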